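The source may report more compounds than this note shows. Statements on the series, on what has been measured and on what is new or still open speak of the compounds shown alone.

Measured so far:
- compound 1 `Cc1cc(C)cc(-n2nncc2CN2C(=O)C3(C(C#N)=C(N)Oc4c3c3nc5ccccc5nc3c3ccccc43)c3ccccc32)c1`: > 50000 nM
- compound 2 `Cc1cccc(-n2nncc2CN2C(=O)C3(C(C#N)=C(N)Oc4c(N)cc5nc6ccccc6nc5c43)c3ccccc32)c1`: > 50000 nM

In an ADME assay on HUVEC cells (Homo sapiens) for antiproliferative activity, read by MTT assay, with a stated time of 48 h (on this read-out higher numbers stand for weaker inhibition and lower numbers for stronger inhibition), compound 1 gives > 50000 nM, which is a limit of the assay and not a number. Compound 2 gives > 50000 nM in this assay, again a limit rather than a measured number. Both values shown sit at the limit of > 50000 nM in this assay, at which 2 of the 2 values shown sit. Compound 2 therefore stands at the limit with no number of its own, and on the figures shown nothing separates it from compound 1; neither compound can be called the weaker or the stronger of the two.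

Compound 3 `CCc1cccc(C)c1-n1nncc1CN1C(=O)C2(C(C#N)=C(N)Oc3c(N)cc4nc5ccccc5nc4c32)c2ccccc21` has yet to be measured in this assay. It differs from compound 2 by 2-ethyl-6-methylphenyl in place of 3-methylphenyl on an aromatic nitrogen. Within the data shown here, no step between measured compounds exists, so the size of the change has to be judged from the two limits alone. Both measured compounds sit at the limit, and the expected step that the limit leaves unreadable from compound 2 to compound 3 is none beyond the usual scatter. Compound 3 is estimated at 60000 nM, within 20000 nM to 200000 nM, and most probably the assay will again report only a limit.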

Compound 3, half-maximal inhibitory concentration: > 50000 nM
Compound 3 ended at the assay's limit; the forecaster's own chance of this, stated with the estimate: 80%; the middle value lies beyond the limit too.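

No step can be read between compound 2 and compound 3 in this assay, and all the series offers is a shared limit: the limit of > 50000 nM in this assay, at which 3 of the 3 values shown sit. The compounds shown leave open whether 2-ethyl-6-methylphenyl in place of 3-methylphenyl changes the read-out at all, and what number any of the three compounds would give.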